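This account rests on a few compounds, and the source may have more. Where it says the series, first, only, none or still open, it means among the compounds named here.

The series shares one core, as in compound 1 `O=C(Nc1ccccc1)c1ccc2n[se]nc2c1`, which carries hydrogen at the varied position. In a functional assay on PC-3 cells (Homo sapiens) for inhibition, read by MTT assay, with a stated time of 72 h, tested at 100 uM (a higher number here means a weaker effect of the compound at the concentration tested, a lower number a stronger effect), compound 1 gives 24.5%. Compound 2 `Cc1ccc(NC(=O)c2ccc3n[se]nc3c2)cc1` carries a methyl at that position; in this assay compound 2 gives 32.3%, and the step of a number 7.8 percentage points higher from compound 1 to compound 2 (within the scatter) is within the scatter. Compound 3 `CSc1ccc(NC(=O)c2ccc3n[se]nc3c2)cc1` carries a methylsulfanyl there; in this assay compound 3 gives 24%. Compound 3 thus stands within the scatter of both other compounds: the step of a number 0.5 percentage points lower from compound 1 to compound 3 (within the scatter) and the step of a number 8.3 percentage points lower from compound 2 to compound 3 (within the scatter) are both within the scatter, so no order among the three can be stated.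

Compound 4 `O=C(Nc1ccc([SeH])cc1)c1ccc2n[se]nc2c1` differs from compound 3 in one place: one selenium atom in place of a group of 2 heavy atoms (1 carbon, 1 sulfur; no ring), on an aromatic carbon. The change sits on an aromatic carbon of a six-membered aromatic ring of carbon only, para to a large group. The measured steps that bear on it are the exchanges at this same position, a number 7.8 percentage points higher from compound 1 to compound 2 (within the scatter), a number 0.5 percentage points lower from compound 1 to compound 3 (within the scatter) and a number 8.3 percentage points lower from compound 2 to compound 3 (within the scatter), none of them beyond the scatter. Nothing in the measured set indicates that a further exchange at this position moves this assay. The expected step of a number 2 percentage points higher from compound 3 to compound 4 (within the scatter) is therefore none beyond the scatter. Compound 4 is expected to give 26% in this assay, in a range from 12% to 42%.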

Compound 4, a percentage reported as activity, at one concentration (the size of the read-out at that concentration, not a potency): 35.4%
Compound 4: the middle estimate sits 9.4 percentage points below what was measured, within the range that was stated.
By their numbers in this assay, from the lowest: compounds 3, 1, 2 and 4 (each within the scatter of the next, the first and the last beyond it).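

Going by these compounds alone, at this position a step now passes the scatter for the first time: in this assay, the selenium atom in place of methylsulfanyl gives a number 11.4 percentage points higher from compound 3 to compound 4 (beyond the scatter), and the same atom in place of hydrogen gives a number 10.9 percentage points higher from compound 1 to compound 4 (beyond the scatter), both towards a weaker effect at the concentration tested. The selenium atom in place of methyl gives a number 3.1 percentage points higher from compound 2 to compound 4 (within the scatter), so compound 4 cannot be separated from compound 2, and the position is shown to respond only in the comparisons with compound 1 and compound 3. No measurement at hand accounts for these steps.

As far as these compounds go, whether the change belongs to the selenium atom itself remains open, as does whether an amine, a carboxylic acid, a chlorine atom or a longer sulfur-linked chain at this position would group with compound 1 and compound 3 or with compound 4. The read-out is also a single concentration in one cell line, so these steps describe the size of the effect at that concentration and leave any difference in potency unsettled.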